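The source may hold more compounds than are shown below. What is called first, only, known or untested is meant among the compounds shown, and "the series" means these compounds.

Working notes on the series. Three compounds share one core and differ only in the group carried on the chain attached to a ring nitrogen. Compound 1 `CCCC[N+]1=C(/C=C/C=C2/N(C)c3ccccc3C2(C)C)C(C)(C)c2ccccc21` carries a plain chain there, and in an assay for displacement of a labelled ligand from protein arginine N-methyltransferase 1 (Homo sapiens), read by scintillation proximity assay, with stated times of 5 min and 8 min, tested at 10 uM (on this read-out lower numbers stand for a weaker effect and higher numbers for a stronger effect at the one concentration tested), compound 1 gives 8%, a weak effect at the single concentration tested. Compound 2 `CN1/C(=C/C=C/C2=[N+](CCCS(=O)(=O)[O-])c3ccccc3C2(C)C)C(C)(C)c2ccccc21` carries on that chain the group made of three oxygen and one sulfur with net charge minus one, and in this assay compound 2 is reported as "not active" (no number reported), with no number given. Compound 2 therefore stands at the bottom of what has been seen so far; how far it lies from compound 1 cannot be told, and the two may sit within the scatter of each other. Compound 3 `CN1/C(=C/C=C/C2=[N+](CCC[N+](C)(C)C)c3ccccc3C2(C)C)C(C)(C)c2ccccc21` is the next member. It differs from compound 2 by a group of 4 heavy atoms (3 carbon, 1 nitrogen; no ring) in place of a group of 4 heavy atoms (3 oxygen, 1 sulfur; no ring), on a saturated chain carbon, three bonds along the chain from a double-bonded nitrogen in a ring. Among the compounds with values here, no step between measured compounds is available to lean on. In this assay the step from compound 2 to compound 3 is expected to be small, either none beyond the scatter or a modest rise, given that compound 1 with an uncharged chain gives only 8%. In this assay compound 3 is expected to give 10%, within a range from 0% to 25%.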

Compound 3, a percentage reported as inhibition, at one concentration (the size of the read-out at that concentration, not a potency): 2%
Compound 3: middle estimate off by 8 percentage points, on the high side; the range from low to high includes it.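

In this assay the saturated chain carbon, three bonds along the chain from a double-bonded nitrogen in a ring, now has a group with net charge +1 to set against the plain chain of compound 1. Putting a group of 4 heavy atoms (3 carbon, 1 nitrogen; no ring) in place of one carbon atom gives a number 6 percentage points lower from compound 1 to compound 3 (within the scatter), so at this position the read-out does not separate the charged group from the plain chain. The step between the groups of opposite net charge cannot be read, as compound 2 is reported as "not active" (no number reported), while compound 3 gives 2%; neither group produces a clear effect at the one concentration tested, and no available measurement speaks to the reason.

As far as these compounds go, whether a primary amine, a carboxylic acid or a longer chain at this position would give a read-out beyond the scatter of compound 1 stays open. Also open, from the compounds shown here alone, is whether a phenyl ring or a hydroxyl group on this chain would behave like the groups seen so far, since all three compounds remain low in this one assay.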